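A few compounds are considered here, and "the series" means these few. Any claim that something is new, unique, unknown or untested is made for them only; others in the source may bear on it.

Within the data shown here, compound 1 `CCN(CC)S(=O)(=O)c1ccc(S(=O)(=O)N2CCC[C@@H](C(=O)NC3CCOCC3)C2)cc1` sits at the top of the three numbers so far: in a functional assay on MIA PaCa-2 cells (Homo sapiens) for inhibition, read by MTT assay, with a stated time of 3 days (a higher number here means a weaker inhibitor, a lower number a stronger inhibitor), compound 1 gives 1350 nM. Compound 3 `CCN(CC)S(=O)(=O)c1ccc(S(=O)(=O)N2CCC[C@@H](C(=O)N3CCS(=O)(=O)CC3)C2)cc1` gives 220 nM, and compound 2 `CN(C)S(=O)(=O)c1ccc(S(=O)(=O)N2CCC[C@@H](C(=O)N3CCC(F)(F)CC3)C2)cc1` gives 72.4 nM. Among the measured compounds shown here, the one step with a single change, a 6.1-fold lower number from compound 1 to compound 3 (0.79 log units; beyond the scatter), shows that exchanging the (oxan-4-yl)amino on the carbonyl carbon for a ring bound directly through its nitrogen brings a clearly lower number. Compound 4 `CCN(CC)S(=O)(=O)c1ccc(S(=O)(=O)N2CCC[C@@H](C(=O)N3CCC(C(F)F)CC3)C2)cc1` differs from compound 1 by 4-(difluoromethyl)piperidin-1-yl in place of (oxan-4-yl)amino on a carbonyl carbon. For the measured compounds named here, only the step from compound 1 to compound 3 bears directly on this; compound 2 differs from compound 1 in two places, and its value can only show that a fluorinated piperidin-1-yl amide reaches a low number in this assay. A lowering beyond the scatter is expected, a 6.8-fold lower number from compound 1 to compound 4 (0.83 log units; beyond the scatter). Compound 4 is estimated at 200 nM, with a range of 60 nM to 650 nM.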

Compound 4, half-maximal inhibitory concentration: 140 nM
For compound 4 the middle estimate is 1.4-fold (0.15 log units) above the measured one, within the range that was stated.
By their numbers in this assay, from the lowest: compounds 2, 4 and 3 (each within the scatter of the next, the first and the last beyond it); then compound 1.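

The lowering at this carbonyl carbon is not tied to 1,1-dioxothiomorpholin-4-yl: in this assay there is a 9.6-fold lower number from compound 1 to compound 4 (0.98 log units; beyond the scatter) with 4-(difluoromethyl)piperidin-1-yl in place of (oxan-4-yl)amino. These two ring amides cannot be told apart, with a 1.6-fold lower number from compound 3 to compound 4 (0.20 log units; within the scatter) here. Nothing measured on these compounds explains the lowering.

Open, on these data alone, is how much of it depends on the difluoromethyl group rather than the piperidin-1-yl ring. Plain piperidin-1-yl and 4-aminopiperidin-1-yl amides on the core of compound 1 would separate the two.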